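Replacing an Amino Link with a Direct Aryl Link

The compounds below may be only part of what the source reports. "The series", "measured", "known", "first", "only" and "open" are said of these compounds alone.

Compound 1: `COc1cc(-c2nn(-c3cccc(NC(=O)c4cccc(C(F)(F)F)c4)c3)cc2-c2ccncc2)ccc1Cl` — > 50000 nM
Compound 2: `COc1cc(-c2nn(-c3cccc(NC(=O)Nc4ccc(Cl)c(Cl)c4)c3)cc2-c2ccncc2)ccc1Cl` — 3110 nM
Compound 3: `COc1cc(-c2nn(-c3cccc(NC(=O)Nc4cccc(C(F)(F)F)c4)c3)cc2-c2ccncc2)ccc1Cl` — 2310 nM

Three compounds sharing one core were tested in a functional assay on UACC-257 cells (Homo sapiens) for inhibition, read by sulforhodamine B assay, with a stated time of 48 h; on this read-out lower numbers stand for stronger inhibition of growth and higher numbers for weaker inhibition of growth. Compound 1 gives a value that is only a limit of this assay, > 50000 nM. Compound 2 gives 3110 nM and compound 3 gives 2310 nM. Compound 3 holds the lowest number of the two that were measured outright, though the gap to compound 2, a 1.3-fold lower number from compound 2 to compound 3 (0.13 log units; within the scatter), lies within the scatter.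

Compound 4, `COc1cc(-c2nn(-c3cccc(NC(=O)c4ccc(Cl)c(C(F)(F)F)c4)c3)cc2-c2ccncc2)ccc1Cl`, has not yet been measured. It differs from compound 3 in one place: 4-chloro-3-(trifluoromethyl)phenyl in place of (3-(trifluoromethyl)phenyl)amino on a carbonyl carbon. The measured steps that bear on this are those that put an amino-bearing group in place of an aryl group directly on the carbonyl carbon: an at least 16-fold lower number from compound 1 to compound 2 (1.20 log units; beyond the scatter) and an at least 21-fold lower number from compound 1 to compound 3 (1.33 log units; beyond the scatter). Compound 4 reverses that kind of change, so the number for compound 4 is expected to rise by a large step, a 17-fold higher number from compound 3 to compound 4 (1.24 log units; beyond the scatter). As far as these compounds go, the added chlorine is untested here, so the estimate carries a wide range: compound 4 is expected to give 40000 nM, between 8000 nM and 200000 nM, with a fair chance that only a limit is reported.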

Compound 4, concentration for total growth inhibition: > 32500 nM
Compound 4 was reported as a limit; the forecaster's own chance of this, stated with the estimate: 55%; the middle value lies beyond the limit too.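

Compound 4 shows that the weak result of compound 1 is not tied to a single aryl group: a second aryl group set directly on the carbonyl carbon, 4-chloro-3-(trifluoromethyl)phenyl, also gives only a limit in this assay, not a number: the limit of > 32500 nM in this assay, at which 1 of the 4 values shown sits.

Set against the two compounds that keep the amino link, the change is large in both cases: an at least 14-fold higher number from compound 3 to compound 4 (1.14 log units; beyond the scatter) and an at least 10-fold higher number from compound 2 to compound 4 (1.01 log units; beyond the scatter). Among these four compounds, an aryl amino group on the carbonyl carbon is present in both compounds with measured numbers and absent from both compounds with limits, and none goes against this.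

As far as these compounds go, the step between compound 1 and compound 4, chloro in place of hydrogen on an aromatic carbon, has limits at both ends and cannot be read, so what that chloro does stays unknown. Also open, from the compounds shown here alone, is whether a different link on the carbonyl carbon, such as a methylene group or an ether oxygen, would give a measurable number.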